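This account rests on a few compounds, and the source may have more. Where it says the series, first, only, none or still open, it means among the compounds named here.

- compound 1 `COc1ccc(/C=C/C(=O)NNC(=O)NCCCC(C)Nc2cc(OC)cc3cccnc23)cc1` gives 3600 nM in this series
- compound 2 `COc1cc(NC(C)CCCNC(=O)NNC(=O)NC2CCCCC2)c2ncccc2c1` gives "not determined" (no result reported) in this series

These entries come from an ADME assay on L6 cells (Rattus norvegicus) for cytotoxicity, read by resazurin assay, with a stated time of 70 h (a higher number here means a weaker inhibitor, a lower number a stronger inhibitor), and they leave one compound without a number. Compound 2 stands at "not determined" (no result reported) as its only entry, so it offers no baseline. The next compound is compound 3 `COc1cc(NC(C)CCCNC(=O)NNC(=O)Nc2ccc(Br)cc2)c2ncccc2c1` which carries 4-bromophenyl in place of cyclohexyl on an amide-type nitrogen, a change counted as 4-bromophenyl in place of cyclohexyl on an amide-type nitrogen here. Going by the values given here, no measured pair shows what this swap does, so no step from compound 2 can be sized in this assay and the data give no direction. Among the compounds with values here, the only anchor is compound 1 at 3600 nM in that read-out, and compound 3 is expected to lie within the scatter of that value. For compound 3 the estimated value is 5000 nM with an expected range from 1800 nM to 15000 nM in this measurement.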

Compound 3, half-maximal inhibitory concentration: 38700 nM
Beside the measured number, compound 3's estimate is 7.7-fold (0.89 log units) below it; the whole stated range lies below it.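

In this assay, (4-bromophenyl)amino in place of 2-(4-methoxyphenyl)ethenyl on a carbonyl carbon gives an 11-fold higher number from compound 1 to compound 3 (1.03 log units; beyond the scatter). Going by these compounds alone, this is the first sign that a change at this end of the molecule, with the rest of the structure held constant, can move the number well beyond the scatter, and it makes compound 3 the weaker inhibitor of the pair. The step between compound 2 and compound 3 cannot be read, and nothing shown explains why the change has an effect of this size.

The compounds shown leave open how much of the step belongs to the bromine and how much to the nitrogen that links the ring to the carbonyl. A plain phenyl or a 4-methoxyphenyl on the same amide-type nitrogen would begin to separate the two.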